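Chain shortening in a hydroxycarbamoyl series: working notes

The compounds below may be only part of what the source reports. "The series", "measured", "known", "first", "only" and "open" are said of these compounds alone.

Measured so far in a functional assay on HEL cells (Homo sapiens) for inhibition; on this read-out lower numbers stand for stronger inhibition and higher numbers for weaker inhibition:
compound 1, `CC(C)c1cc(-c2n[nH]c(=O)n2-c2cccc(C(=O)NCCCCCC(=O)NO)c2)c(O)cc1O`, gives 4600 nM.
compound 2, `CC(C)c1cc(-c2n[nH]c(=O)n2-c2cccc(C(=O)NCCCCCCC(=O)NO)c2)c(O)cc1O`, gives 4600 nM.
compound 3, `CC(C)c1cc(-c2n[nH]c(=O)n2-c2ccc(C(=O)NCCCCCC(=O)NO)cc2)c(O)cc1O`, gives 4600 nM.

Within the data shown here, compound 2 and compound 1 differ in one place, (hydroxycarbamoyl in place of (hydroxycarbamoyl)methyl on a saturated chain carbon, five bonds along the chain from an amide-type nitrogen), and the step of no change at the digits printed from compound 2 to compound 1 (within the scatter) is the only measured instance of this change so far. Compound 3 carries the same chain as compound 1 on a differently built core; how the core of compound 2 and the core of compound 3 differ is not broken down here, and the values of compound 2 and compound 3 in this assay simply lie within the scatter of each other.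

Compound 4, `CC(C)c1cc(-c2n[nH]c(=O)n2-c2ccc(C(=O)NCCCCC(=O)NO)cc2)c(O)cc1O`, has not yet been measured. It differs from compound 3 by hydroxycarbamoyl in place of (hydroxycarbamoyl)methyl on a saturated chain carbon, four bonds along the chain from an amide-type nitrogen. The place is not identical to that of the measured pair: there the chain carbon stood five bonds along the chain from an amide-type nitrogen, here four bonds, so this is the same kind of change rather than the same change.

Among the measured compounds shown here, because no change at the digits printed from compound 2 to compound 1 (within the scatter) shows no movement for the one measured instance, the step from compound 3 to compound 4 is expected to be no change at the digits printed from compound 3 to compound 4 (within the scatter). Compound 4 is therefore estimated at 4600 nM in this assay, with an expected range from 2300 nM to 9200 nM. This expectation rests on a single measured pair and on a change that occurs only twice among the compounds shown.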

Compound 4, half-maximal inhibitory concentration: 4600 nM
For compound 4 middle estimate and measured number coincide at the digits printed, and the stated range covers the measured number.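

In this assay the new step reads no change at the digits printed from compound 3 to compound 4 (within the scatter), and set beside the earlier step on the other core it gives the same outcome: the same change on two cores in this assay, no change at the digits printed (within the scatter) from compound 2 to compound 1 and no change at the digits printed (within the scatter) from compound 3 to compound 4, 1.0-fold (0.00 log units) apart, within the scatter of two such steps

Replacing (hydroxycarbamoyl)methyl with hydroxycarbamoyl therefore carries from one core to the other without a visible difference in this read-out, in two instances, with the chain carbon five bonds along the chain from an amide-type nitrogen in one and four bonds along in the other. This does not show that the change is silent in general: both steps are flat, so the comparison tests transfer only where nothing moves, and it cannot tell whether a step of real size would carry across these two cores in the same way.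

The compounds shown leave open whether a longer chain, or a shorter one such as 2-(hydroxycarbamoyl)ethyl, would move the value away from the level shared by all four compounds. They also leave open whether a carboxylic acid or an amine at the chain end, in place of hydroxycarbamoyl, would stay at that level on either core.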